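A Chloro Moved Within the Shared Core

The source may hold more compounds than are shown below. What is called first, only, known or untested is meant among the compounds shown, and "the series" means these compounds.

Compound 1 `COc1ccccc1S(=O)(=O)/C=C/c1ccccn1` stands highest of the two numbers measured in an ADME assay on BV-2 cells (Mus musculus) for cytotoxicity, with a stated time of 24 h, tested at 50 uM (on this read-out lower numbers stand for a stronger effect and higher numbers for a weaker effect at the one concentration tested), giving 100%. Its nearest comparator, compound 2 `COc1ccccc1S(=O)(=O)/C=C/c1cccc(Cl)n1`, gives 80.5% in this assay, a step of a number 19.5 percentage points lower from compound 1 to compound 2 (beyond the scatter). Compound 3 `COc1ccccc1S(=O)(=O)/C=C/c1ccc(Cl)cn1` differs from compound 1 by chloro in place of hydrogen on an aromatic carbon, a change of the same kind as that leading to compound 2, at another place on the same ring. Among the compounds with values here, since the one comparable step was a number 19.5 percentage points lower from compound 1 to compound 2 (beyond the scatter), a modest drop is expected for compound 3, namely a number 15 percentage points lower from compound 1 to compound 3 (beyond the scatter) in this assay. Compound 3 is accordingly estimated at 85%, between 65% and 100%.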

Compound 3, a percentage reported as activity, at one concentration (the size of the read-out at that concentration, not a potency): 92.6%
For compound 3 the middle estimate is 7.6 percentage points below the measured one; the measured number falls inside the stated range.
By their numbers in this assay, from the lowest: compound 2; then compounds 3 and 1 (each within the scatter of the next).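

At this place, two atoms from the ring nitrogen and para to a large group, chloro in place of hydrogen gives a number 7.4 percentage points lower from compound 1 to compound 3 (within the scatter) in this assay. The same exchange at the other place on this ring gave a number 19.5 percentage points lower from compound 1 to compound 2 (beyond the scatter), so among these compounds a step beyond the scatter comes with one place only, not with chloro at either place. Nothing measured here explains that difference.

Going by these compounds, it remains open how an amine, a carboxylic acid or bromo at this place would read in this assay.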